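The compounds below may be only part of what the source reports. "The series", "measured", "known", "first", "only" and "open" are said of these compounds alone.

Measured so far:
Compound 1 `Cc1ccccc1C(=O)Nc1cccc(-c2oc3cc(-c4ccc(F)cc4)ccc3c(=O)c2O)c1` gives 11900 nM in a functional assay on HeLa cells (Homo sapiens) for antiproliferative activity, read by CCK-8 assay, with a stated time of 72 h; on this read-out lower numbers stand for stronger inhibition and higher numbers for weaker inhibition.
Compound 2 `O=C(Nc1cccc(-c2oc3cc(-c4ccc(F)cc4)ccc3c(=O)c2O)c1)c1cccc(F)c1` gives 8780 nM in this assay.

Going by the values given here, compound 2 stands at the lower of the two numbers, yet the only step that reaches it, a 1.4-fold lower number from compound 1 to compound 2 (0.13 log units; within the scatter), lies within the scatter, so the two compounds are not separated by this read-out. Compound 3 `COc1ccc(C(=O)Nc2cccc(-c3oc4cc(-c5ccc(F)cc5)ccc4c(=O)c3O)c2)c(F)c1` differs from compound 2 by 2-fluoro-4-methoxyphenyl in place of 3-fluorophenyl on a carbonyl carbon. Among the compounds with values here, the one measured step, a 1.4-fold lower number from compound 1 to compound 2 (0.13 log units; within the scatter), also exchanged the ring on this carbonyl carbon and moved the number by less than the scatter; no measured compound carries a methoxy group on that ring, so the data give no direct guide to it. Compound 3 is therefore expected to sit close to compound 2, with a step of a 1.1-fold lower number from compound 2 to compound 3 (0.04 log units; within the scatter) that is not beyond the scatter. The estimate for compound 3 in this assay is 8000 nM, within a range from 3000 nM to 22000 nM.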

Compound 3, half-maximal inhibitory concentration: 16100 nM
Estimate against measurement, compound 3: 2.0-fold (0.30 log units) below, within the range that was stated.
By their numbers in this assay, from the lowest: compounds 2, 1 and 3 (each within the scatter of the next).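

In this assay, 2-fluoro-4-methoxyphenyl on the carbonyl carbon gives a 1.8-fold higher number from compound 2 to compound 3 (0.26 log units; within the scatter) and a 1.4-fold higher number from compound 1 to compound 3 (0.13 log units; within the scatter), so a ring carrying a methoxy group on this carbon is not separated by this read-out from either earlier ring. The entering group has 9 heavy atoms and 1 hydrogen-bond acceptor, against 7 and 0 for 3-fluorophenyl, and even this larger exchange stays within the scatter. Nothing further is available to explain how close the three compounds lie.

On these data alone, it remains open whether any group on this carbonyl carbon can move the number beyond the scatter, since all three compounds carry a substituted phenyl ring there and none carries an amine or a carboxylic acid on it. The amide and the rest of the core are the same in all three compounds, so the effect of a change elsewhere is also unknown.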